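The compounds below may be only part of what the source reports. "The series", "measured", "known", "first", "only" and "open" are said of these compounds alone.

Measured in a functional assay on C6 cells (Rattus norvegicus) for cytotoxicity, read by MTT assay, with a stated time of 24 h, tested at 200 ug/mL; on this read-out higher numbers stand for a weaker effect at the one concentration tested and lower numbers for a stronger effect:

- compound 1, `Cc1ccc(-c2cs/c(=N/NC(=O)CSc3nnnn3-c3ccccc3)n2-c2ccccc2)cc1`, gives 22.2%
- compound 2, `O=C(CSc1nnnn1-c1ccccc1)N/N=c1/scc(-c2ccc(F)cc2)n1-c1ccccc1`, gives 30.6%
- compound 3, `O=C(CSc1nnnn1-c1ccccc1)N/N=c1/scc(-c2ccccc2)n1-c1ccccc1`, gives 22.6%

Compound 2 holds the highest of the three numbers, yet this says little, since its nearest neighbour is compound 3 with a number 8 percentage points lower from compound 2 to compound 3 (within the scatter) and the step of a number 8.4 percentage points higher from compound 1 to compound 2 (within the scatter) is also within the scatter. The three compounds cannot be ordered on what has been measured.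

Compound 4, `O=C(CSc1ncccn1)N/N=c1/scc(-c2ccc(F)cc2)n1-c1ccccc1`, takes the series in a new direction. Relative to compound 2 it differs as follows: pyrimidin-2-yl in place of 1-phenyl-1H-tetrazol-5-yl on a sulfur. Among the measured compounds shown here, none of the measured steps touches this sulfur substituent; every one of them, including a number 0.4 percentage points higher from compound 1 to compound 3 (within the scatter), concerns only the substituent on the aromatic carbon, and each of them lay within the scatter. For the measured compounds named here, there is therefore no measured step that bears on the change from compound 2 to compound 4, and no direction can be read from the data.

With nothing to lean on but the flat run of the three measured compounds, the estimate for compound 4 in this assay is 30%, within a range from 12% to 55%, so that the expected step of a number 0.6 percentage points lower from compound 2 to compound 4 (within the scatter) stays within the scatter.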

Compound 4, a percentage reported as activity, at one concentration (the size of the read-out at that concentration, not a potency): 32.2%
For compound 4 the middle estimate is 2.2 percentage points below the measured one; the range from low to high includes it.
By their numbers in this assay, from the lowest: compounds 1, 3, 2 and 4 (each within the scatter of the next).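

Until compound 4, every step in the series concerned only the substituent on the aromatic carbon, so nothing was known about the sulfur substituent. In this assay, replacing 1-phenyl-1H-tetrazol-5-yl, with 11 heavy atoms in two aromatic rings and 4 hydrogen-bond acceptors, by pyrimidin-2-yl, with 6 heavy atoms in one aromatic ring and 2 hydrogen-bond acceptors, gives a number 1.6 percentage points higher from compound 2 to compound 4 (within the scatter), so this large change in the group on the sulfur produces no difference that can be read at the one concentration tested. No measurement is available that would account for this result.

As far as these compounds go, it remains open whether a different kind of group on this sulfur, such as a plain methyl, an amine-bearing chain or a chain ending in a carboxylic acid, would give a step beyond the scatter. Also unresolved is whether pyrimidin-2-yl would give the same result with methyl or hydrogen on the aromatic carbon in place of fluoro, and how these compounds would compare across a range of concentrations rather than at a single one.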